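From Phenoxy to Dimethylamino: What the Numbers Allow

The compounds below may be only part of what the source reports. "The series", "measured", "known", "first", "only" and "open" are said of these compounds alone.

Measured so far in a functional assay on OVCAR-4 cells (Homo sapiens) for cytotoxicity, read by sulforhodamine B assay, with a stated time of 48 h, tested at 1 uM; on this read-out higher numbers stand for a weaker effect at the one concentration tested and lower numbers for a stronger effect:
- compound 1 `COc1cc(C)cc(-c2c(-c3ccnc(-c4ccc(C(C)=O)cc4)c3)cnn2CC#N)c1` gives 27%
- compound 2 `COc1cc(C)cc(-c2nn(CC#N)cc2-c2ccc(-c3cccc(C(C)=O)c3)nc2)c1` gives 19%
- compound 3 `Cc1cc(O)cc(-c2nn(CC#N)cc2-c2ccnc(-c3ccc(Oc4ccccc4)cc3)c2)c1` gives 21%

Compound 3 stands second highest of the three numbers on this read-out. Among the measured compounds shown here, its nearest neighbour is compound 2, and the furthest is compound 1; both gaps fall within the usual scatter of repeated measurements, so the three compounds cannot be told apart on these figures, and no single step between two measured compounds has been worked out.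

Compound 4 `Cc1cc(O)cc(-c2nn(CC#N)cc2-c2ccnc(-c3ccc(N(C)C)cc3)c2)c1` has not yet been measured. It differs from compound 3 in one place: dimethylamino in place of phenoxy on an aromatic carbon, para to a large group.

No measured pair isolates this change, so no shown step can serve as a guide. Given that the three measured compounds sit together within the scatter, compound 4 is expected to land in the same neighbourhood, and the step of a number 3 percentage points higher from compound 3 to compound 4 (within the scatter) is estimated to be none beyond the scatter, with no direction favoured. Compound 4 is therefore estimated at 24%, within a range of 8% to 45%.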

Compound 4, a percentage reported as activity, at one concentration (the size of the read-out at that concentration, not a potency): 27%
For compound 4 the middle estimate is 3 percentage points below the measured one, and the stated range covers the measured number.
By their numbers in this assay, from the lowest: compounds 2, 3, 1 and 4 (each within the scatter of the next).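

In this assay, among the compounds shown here, dimethylamino in place of phenoxy on an aromatic carbon, para to a large group, gives a number 6 percentage points higher from compound 3 to compound 4 (within the scatter) and offers the first reading of a single change. At this position, the six-membered aromatic ring of carbon only goes with the phenoxy group and the heavy atoms fall from 7 to 3, yet the step stays within the scatter, while the hydrogen-bond acceptor and donor counts are the same on both sides. This pair therefore shows that, with the rest of compound 3 held constant, a large aromatic ether and a small ringless amine cannot be told apart at the single concentration tested, and no measurement shown explains this outcome.

The compounds shown leave open whether a carboxylic acid, a morpholine ring or a longer alkyl chain at this position would move the read-out beyond the scatter. Compound 1 and compound 2 differ from the others in more than one place, so their steps cannot be read, and the roles of the hydroxyl, the methoxy and the acetyl group remain unresolved.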